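The source may hold more compounds than are shown below. What is called first, only, known or untested is meant among the compounds shown, and "the series" means these compounds.

Measured in a functional assay on MCF7 cells (Homo sapiens) for cytotoxicity, read by MTT assay, with a stated time of 96 h; on this read-out lower numbers stand for stronger inhibition and higher numbers for weaker inhibition:
- compound 1 `COc1cc(C(=O)c2cn(-c3ccccc3)cc2-c2ccc([N+](=O)[O-])cc2)cc(OC)c1OC`: 590 nM
- compound 2 `COc1cc(C(=O)c2cn(-c3cccc(N)c3)cc2-c2ccccc2[N+](=O)[O-])cc(OC)c1OC`: 14 nM

Compound 2 has the lower number of the pair, and its gap to compound 1 lies beyond the usual scatter. Compound 3 `COc1cc(C(=O)c2cn(-c3cccc(N)c3)cc2-c2ccc([N+](=O)[O-])cc2)cc(OC)c1OC` keeps the 3-aminophenyl group of compound 2 but differs from it in one place: 4-nitrophenyl in place of 2-nitrophenyl on an aromatic carbon. Within the data shown here, no measured pair isolates this change. Compound 3 shares its 4-nitrophenyl with compound 1, which gives 590 nM, so some loss of inhibition seems likely. The expected change is modest, a 2.9-fold higher number from compound 2 to compound 3 (0.46 log units; beyond the scatter). For compound 3 the estimated value is 40 nM, with an expected range of 10 nM to 200 nM.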

Compound 3, half-maximal inhibitory concentration: 110 nM
Beside the measured number, compound 3's estimate is 2.8-fold (0.44 log units) below it; low and high end bracket the measured number.
By their numbers in this assay, from the lowest: compound 2; then compound 3; then compound 1.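

In this assay, this place on the five-membered aromatic ring responds to where the nitro group sits: with the same atoms, 4-nitrophenyl in place of 2-nitrophenyl gives a 7.9-fold higher number from compound 2 to compound 3 (0.90 log units; beyond the scatter) as the step. With 4-nitrophenyl kept, amino in place of hydrogen gives a 5.4-fold lower number from compound 1 to compound 3 (0.73 log units; beyond the scatter) as its step, so the 3-aminophenyl group also counts. Nothing available explains either step.

Still open, as far as these compounds go, is how a plain phenyl, or a phenyl carrying a nitrile or a carboxylic acid instead of the nitro group, would behave at this place. Also open, from the compounds shown here alone, is whether amino in place of hydrogen gives a similar step when 2-nitrophenyl is present.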